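Swapping 1,1-difluoroethyl for ethoxy: a clearance forecast

A few compounds are considered here, and "the series" means these few. Any claim that something is new, unique, unknown or untested is made for them only; others in the source may bear on it.

- Compound 1 `CCOc1nc2nc(C)cc(Nc3ccc(C(F)(F)F)cc3)n2n1`: 7 mL.min-1.g-1
- Compound 2 `Cc1cc(Nc2ccc(S(F)(F)(F)(F)F)cc2)n2nc(C(C)(F)F)nc2n1`: < 5 mL.min-1.g-1

In an in vitro ADME assay on microsomes from liver (Homo sapiens) for metabolic stability (a higher number here means faster removal of the compound, a lower number slower removal), compound 2 gives < 5 mL.min-1.g-1, which is a limit of the assay and not a number. Compound 2 stands at the limit of < 5 mL.min-1.g-1 in this assay, at which 1 of the 2 values shown sits.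

Compound 3 `CCOc1nc2nc(C)cc(Nc3ccc(S(F)(F)(F)(F)F)cc3)n2n1` has not yet been measured. It differs from compound 2 in one group: ethoxy in place of 1,1-difluoroethyl on an aromatic carbon. This puts ethoxy in place of 1,1-difluoroethyl on an aromatic carbon, between two ring nitrogen atoms.

Among the measured compounds shown here, no measured pair of compounds isolates this change, so its size can only be judged roughly. Compound 1 also carries ethoxy, and compound 1 gives 7 mL.min-1.g-1, a true number rather than a limit. It differs from compound 3 elsewhere in the structure, so it is only a loose guide. On the strength of that one value, a modest upward step is expected, with an estimated at least 1.6-fold higher number from compound 2 to compound 3 (0.20 log units; that floor lies within the scatter), and it may not clear the usual scatter. For compound 3 the expected value is 8 mL.min-1.g-1, with an estimated range from 5 mL.min-1.g-1 to 15 mL.min-1.g-1.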

Compound 3, intrinsic clearance in microsomes: < 5 mL.min-1.g-1
Compound 3 ended at the assay's limit; the forecaster's own chance of this, stated with the estimate: 25%; middle value at least 1.6-fold (0.20 log units) away from the limit.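

In this assay compound 3 gives < 5 mL.min-1.g-1, which is a limit of the assay and not a number, so ethoxy on this aromatic carbon, between two ring nitrogen atoms, does not lift the read-out to a measurable value when the group of 6 heavy atoms is also present. With ethoxy held fixed, putting that group of 6 heavy atoms (5 fluorine, 1 sulfur) in place of the group of 4 heavy atoms (1 carbon, 3 fluorine) gives an at least 1.4-fold lower number from compound 1 to compound 3 (0.14 log units; that floor lies within the scatter), so a real difference between these two compounds is possible but not established. The swap of 1,1-difluoroethyl for ethoxy itself cannot be read, because both of its ends are limits: the limit of < 5 mL.min-1.g-1 in this assay, at which 2 of the 3 values shown sit.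

The compounds shown leave open how far compound 2 and compound 3 truly lie apart, and whether ethoxy and 1,1-difluoroethyl differ at all at this position. They also leave open whether a longer chain such as butoxy, or an amine, on the same aromatic carbon would bring the read-out up to a measurable value.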